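The source may report more compounds than this note shows. Statements on the series, on what has been measured and on what is new or still open speak of the compounds shown alone.

In a functional assay on EBC-1 cells (Homo sapiens) for antiproliferative activity, read by sulforhodamine B assay, with a stated time of 72 h (a higher number here means a weaker inhibitor, a lower number a stronger inhibitor), compound 1 `Cn1cc(-c2ccc(=O)n(CCOc3ccnc4cc(OCCCC(=O)NO)ccc34)n2)cn1` gives 870 nM, compound 2 `Cn1cc(-c2ccc(=O)n(CCOc3ccnc4cc(OCCCCC(=O)NO)ccc34)n2)cn1` gives 370 nM and compound 3 `Cn1cc(-c2ccc(=O)n(CCOc3ccnc4cc(OCCCCCS)ccc34)n2)cn1` gives 640 nM. That last value lies within the scatter of the other two: a 1.4-fold lower number from compound 1 to compound 3 (0.13 log units; within the scatter) and a 1.7-fold higher number from compound 2 to compound 3 (0.24 log units; within the scatter). Compound 4 `CC(=O)CCCCCOc1ccc2c(OCCn3nc(-c4cnn(C)c4)ccc3=O)ccnc2c1` brings a new structural change: acetyl in place of sulfanyl on a saturated chain carbon, five bonds along the chain from an oxygen on an aromatic ring. Among the measured compounds shown here, no compound measured so far carries acetyl, so the evidence is indirect. The other replacements at this chain position moved the number little, and the largest shift, a 2.4-fold lower number from compound 1 to compound 2 (0.37 log units; beyond the scatter), is modest. No step beyond the scatter is therefore expected in this assay. The expected step is a 1.1-fold lower number from compound 3 to compound 4 (0.03 log units; within the scatter). For compound 4 the estimated value is 600 nM, with an expected range from 220 nM to 1600 nM.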

Compound 4, half-maximal inhibitory concentration: 25 nM
The estimate for compound 4 lay 24-fold (1.38 log units) above the measured number; the whole stated range lies above it.
By their numbers in this assay, from the lowest: compound 4; then compounds 2, 3 and 1 (each within the scatter of the next, the first and the last beyond it).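

In this assay, among the compounds shown here, the end of this chain matters far more than the earlier compounds suggested: acetyl in place of sulfanyl gives a 26-fold lower number from compound 3 to compound 4 (1.41 log units; beyond the scatter). Set against the two hydroxycarbamoyl compounds, the acetyl-ended chain gives a 15-fold lower number from compound 2 to compound 4 (1.17 log units; beyond the scatter) and a 35-fold lower number from compound 1 to compound 4 (1.54 log units; beyond the scatter), so the earlier near-equal values did not mean that this place tolerates any change without effect. Nothing measured here explains this gain. Going by these compounds, it remains open whether the gain depends on the carbonyl or on the whole acetyl group. A carboxylic acid, an amine or a longer chain ending in acetyl would help to separate these possibilities.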